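Swapping the Hydroxyphenyl Group for a Furanylmethyl Group

The source may report more compounds than this note shows. Statements on the series, on what has been measured and on what is new or still open speak of the compounds shown alone.

Of the compounds shown here, three built on one shared core have been tested in a functional assay on L02 cells (Homo sapiens) for inhibition, read by Griess assay, with stated times of 1 h and 24 h; on this read-out higher numbers stand for weaker inhibition and lower numbers for stronger inhibition. Compound 1, `COc1cc(/C=C/c2nc(Nc3ccc(C)cc3)c3sccc3n2)cc(OC)c1OC`, gives only a limit in this assay, < 40000 nM. Compound 2, `COc1ccc(Nc2nc(/C=C/c3cc(OC)c(OC)c(OC)c3)nc3ccsc23)cc1`, gives 279000 nM in this assay. Compound 3, `COc1cc(/C=C/c2nc(Nc3ccc(O)cc3)c3sccc3n2)cc(OC)c1OC`, also gives only a limit in this assay, > 1000000 nM. Among the three, compound 3 therefore stands at the weak end: every step leading to it is beyond the scatter.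

Every measured step alters the group on the ring nitrogen of the core. There is an at least 6.9-fold higher number from compound 1 to compound 2 (0.84 log units; beyond the scatter), there is an at least 25-fold higher number from compound 1 to compound 3 (1.39 log units; beyond the scatter), and there is an at least 3.5-fold higher number from compound 2 to compound 3 (0.55 log units; beyond the scatter). Each shift is beyond the scatter, so this position is one where the read-out moves readily.

Compound 4, `COc1cc(/C=C/c2nc(NCc3ccco3)c3sccc3n2)cc(OC)c1OC`, differs from compound 3 by (furan-2-yl)methyl in place of 4-hydroxyphenyl on a nitrogen on an aromatic ring. Among the measured compounds shown here, none of the measured steps is this same exchange, so the direction can only be judged from the fact that compound 3 already sits at a limit and that the other two compounds, with different groups on this nitrogen, give lower numbers. A move back toward those is expected, giving an estimated at least 5.0-fold lower number from compound 3 to compound 4 (0.69 log units; beyond the scatter). Compound 4 is expected to give about 200000 nM in this assay, with a range from 30000 nM to 1500000 nM.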

Compound 4, half-maximal inhibitory concentration: 189000 nM
Compound 4: the middle estimate sits 1.1-fold (0.02 log units) above what was measured; low and high end bracket the measured number.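

There is a 1.5-fold lower number from compound 2 to compound 4 (0.17 log units; within the scatter), so in this assay a (furan-2-yl)methyl group on this nitrogen cannot be told apart from a 4-methoxyphenyl group, and a six-membered aromatic ring of carbon only is not needed to reach that level. There is also an at least 5.2-fold lower number from compound 3 to compound 4 (0.72 log units; beyond the scatter), which shows that the weak end occupied by compound 3 goes with 4-hydroxyphenyl and not with every change at this position, although this step is read against a limit for compound 3: the limit of > 1000000 nM in this assay, at which 1 of the 4 values shown sits. Yet there is an at least 4.7-fold higher number from compound 1 to compound 4 (0.67 log units; beyond the scatter), so the new group does not match 4-methylphenyl, and this step too is read against a limit, here for compound 1: the limit of < 40000 nM in this assay, at which 1 of the 4 values shown sits.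

The compounds shown leave open whether the furan ring or the methyl link in the new group counts for more, and a benzyl group or a longer chain such as 2-(furan-2-yl)ethyl on the same nitrogen would help separate the two. Also open, from the compounds shown here alone, is how far compound 1 and compound 3 really lie from their limits, and with that the true size of every step that involves them.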